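A few compounds are considered here, and "the series" means these few. Any claim that something is new, unique, unknown or untested is made for them only; others in the source may bear on it.

Measured so far:
Compound 1 `CN1CCN(c2nccc3nc(-c4ccc(F)c(F)c4)[nH]c23)CC1`: 130000 nM
Compound 2 `O=C1CN(c2nccc3[nH]c(-c4ccc(F)c(F)c4)nc23)CCN1`: < 5000 nM
Compound 3 `NC1CCN(c2nccc3[nH]c(-c4cccc(OC(F)(F)F)c4)nc23)CC1`: 200000 nM

In a physicochemical assay for solubility, read by HPLC, using the shake flask method, in phosphate buffer, with a stated time of 20 h, at pH 6.5 (a lower number here means a less soluble compound, a higher number a more soluble compound), compound 3 gives 200000 nM, and compound 1 gives 130000 nM, so the two stand within the scatter of each other. Compound 2 gives < 5000 nM, which is a limit of the assay and not a number.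

Compound 4 `NCC1CCN(c2nccc3[nH]c(-c4cccc(OC(F)(F)F)c4)nc23)CC1` differs from compound 3 in one place: aminomethyl in place of amino on a saturated ring carbon. It carries aminomethyl in place of amino on a saturated ring carbon, that is, 4-(aminomethyl)piperidin-1-yl instead of 4-aminopiperidin-1-yl. For the measured compounds named here, no measured pair shows this change, so the expectation in this assay starts from compound 3 at 200000 nM. The expected step, a 1.2-fold lower number from compound 3 to compound 4 (0.07 log units; within the scatter), stays within the scatter. For compound 4 the estimated value is 170000 nM, with an expected range of 60000 nM to 400000 nM.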

Compound 4, solubility: 200000 nM
Compound 4: the middle estimate sits 1.2-fold (0.07 log units) below what was measured; the range from low to high includes it.
By their numbers in this assay, from the lowest: compounds 1, 3 and 4 (each within the scatter of the next). At a limit, below all of these: compound 2.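

For the compounds shown here, this is the first pair in the set that differs in one place. In this assay the step reads no change at the digits printed from compound 3 to compound 4 (within the scatter), so on this saturated ring carbon of the core of compound 3, amino and aminomethyl stand level. Nothing in the data gives a reason for this flat step.

As far as these compounds go, whether a longer chain such as aminoethyl, or a carboxylic acid, on the same ring carbon would also stand level remains open. So does whether this change reads the same with the aryl group of compound 1.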